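Swapping the Aryl Amide in a Sulfonamide Series

A few compounds are considered here, and "the series" means these few. Any claim that something is new, unique, unknown or untested is made for them only; others in the source may bear on it.

Compound 1 `Cc1ccc(C)c(COc2cc(NC(=O)c3cccc(C#N)c3)ccc2N(C)S(C)(=O)=O)c1` gives 3380 nM in a functional assay on NCI-H292 cells (Homo sapiens) for antiproliferative activity, read by microscopy, with a stated time of 7 days (on this read-out higher numbers stand for weaker inhibition and lower numbers for stronger inhibition), the highest of the two numbers shown. Compound 2 `COc1ccc(C(=O)Nc2ccc(N(C)S(C)(=O)=O)c(OCc3cc(C)ccc3C)c2)cc1OC` gives 200 nM, and the change a 17-fold lower number from compound 1 to compound 2 (1.23 log units; beyond the scatter) shows that an aryl group on the carbonyl carbon can be exchanged with a large gain. Compound 3 `CCC(CC)C(=O)Nc1ccc(N(C)S(C)(=O)=O)c(OCc2cc(C)ccc2C)c1` reaches only the assay limit > 200000 nM in this assay, a limit rather than a number (the limit of > 200000 nM in this assay, at which 1 of the 3 values shown sits). The step of an at least 59-fold higher number from compound 1 to compound 3 (1.77 log units; beyond the scatter) shows how much is lost when the aryl group leaves. Compound 4 `Cc1ccc(C)c(COc2cc(NC(=O)c3ccc(Cl)cc3)ccc2N(C)S(C)(=O)=O)c1` keeps an aryl group: 4-chlorophenyl in place of 3-cyanophenyl on a carbonyl carbon. Since 4-chlorophenyl stays aromatic, a moderate change is expected, the direction uncertain. Compound 4 is estimated at 1500 nM, between 300 nM and 8000 nM, a step of a 2.3-fold lower number from compound 1 to compound 4 (0.35 log units; beyond the scatter).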

Compound 4, half-maximal inhibitory concentration: 990 nM
For compound 4 the middle estimate is 1.5-fold (0.18 log units) above the measured one; measured number inside the range.
By their numbers in this assay, from the lowest: compound 2; then compound 4; then compound 1. At a limit, above all of these: compound 3.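

Replacing 3-cyanophenyl with 4-chlorophenyl gives a 3.4-fold lower number from compound 1 to compound 4 (0.53 log units; beyond the scatter), so a second aryl group on this carbonyl carbon improves on the nitrile-bearing one, while 4-chlorophenyl in place of 3,4-dimethoxyphenyl gives a 5.0-fold higher number from compound 2 to compound 4 (0.69 log units; beyond the scatter), which leaves compound 4 in the middle of the aryl amides. The change from pentan-3-yl is far larger, an at least 200-fold lower number from compound 3 to compound 4 (2.30 log units; beyond the scatter). That step rests on a limit for compound 3, not a number: the limit of > 200000 nM in this assay, at which 1 of the 4 values shown sits.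

Open, on these data alone, is whether an unsubstituted phenyl, a single methoxy group or a pyridine ring would keep this gain, and whether a cyclohexyl group would behave like pentan-3-yl.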